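The source may report more compounds than this note shows. Statements on the series, on what has been measured and on what is new or still open speak of the compounds shown alone.

In an ADME assay on Vero cells (Chlorocebus sabaeus) for cytotoxicity, read by MTT assay (on this read-out higher numbers stand for lower toxicity in this test and lower numbers for higher toxicity in this test), compound 1 `Cn1nc(C(F)(F)F)cc1C(=O)Nc1ccc(S(=O)(=O)N2CCCCC2)cc1` gives > 300000 nM, which is a limit of the assay and not a number. For the measured compounds named here, compound 2 `Cn1nc(C(F)(F)F)cc1C(=O)Nc1ccc(S(=O)(=O)n2ccc3ccccc32)cc1` gives 13000 nM, the only true number so far. Compound 3 `Cn1nc(C(F)(F)F)cc1C(=O)Nc1ccc(S(=O)(=O)N2CCC(C(F)(F)F)CC2)cc1` has 4-(trifluoromethyl)piperidin-1-yl in place of the 1H-indol-1-yl on the sulfonyl sulfur of compound 2 (4-(trifluoromethyl)piperidin-1-yl in place of 1H-indol-1-yl on a sulfonyl sulfur). Going by the values given here, one measured step bears on this change: an at least 23-fold lower number from compound 1 to compound 2 (1.36 log units; beyond the scatter), a large step beyond the scatter, with piperidin-1-yl leaving and 1H-indol-1-yl entering. Among the compounds with values here, compound 3 reverses most of that swap, but no measured compound shows what the added trifluoromethyl does. Going by compound 1 and the step of an at least 23-fold lower number from compound 1 to compound 2 (1.36 log units; beyond the scatter), a large rise in the number is expected, possibly back to the limit. The expected step is a 12-fold higher number from compound 2 to compound 3 (1.06 log units; beyond the scatter). For compound 3 the estimated value is 150000 nM, within an expected range of 40000 nM to 300000 nM.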

Compound 3, half-maximal cytotoxic concentration: 159000 nM
Estimate against measurement, compound 3: 1.1-fold (0.03 log units) below; low and high end bracket the measured number.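

In this assay, the change back to a non-aromatic ring gives a 12-fold higher number from compound 2 to compound 3 (1.09 log units; beyond the scatter), so among these compounds the low number of compound 2 now stands apart from two piperidine-type groups rather than just one. Compound 1 gives > 300000 nM, which is a limit of the assay and not a number. Trifluoromethyl in place of hydrogen on a saturated ring carbon gives an at least 1.8-fold lower number from compound 1 to compound 3 (0.27 log units; that floor lies within the scatter), so this pair shows no clear effect of the added group, and the true size of the step remains unknown: the limit of > 300000 nM in this assay, at which 1 of the 3 values shown sits.

The compounds shown leave open how the number would respond to a morpholin-4-yl ring or a simple open-chain amine on the sulfonyl sulfur. They also leave open whether the low number goes with the five-membered or the six-membered aromatic ring of 1H-indol-1-yl.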